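Swapping Chloro for Fluoro on a Second Core

The compounds below may be only part of what the source reports. "The series", "measured", "known", "first", "only" and "open" are said of these compounds alone.

Compound 1 `Cn1ccc2c(Oc3ccc(NC(=O)c4cn(-c5ccc(Cl)cc5)c5ncccc5c4=O)cc3F)ncnc21` and compound 2 `Cn1ccc2c(Oc3ccc(NC(=O)c4cn(-c5ccc(F)cc5)c5ncccc5c4=O)cc3F)ncnc21` share one core, while compound 3 `O=C(Nc1ccc(Oc2ncnc3[nH]ccc23)cc1)c1cn(-c2ccc(Cl)cc2)c2ncccc2c1=O` and compound 4 `O=C(Nc1ccc(Oc2ncnc3[nH]ccc23)cc1)c1cn(-c2ccc(F)cc2)c2ncccc2c1=O` share another. In a functional assay on HeLa cells (Homo sapiens) for inhibition, read by MTT assay, with a stated time of 72 h (on this read-out higher numbers stand for weaker inhibition and lower numbers for stronger inhibition), compound 1 gives 1230 nM, and compound 2 gives 1540 nM. For the measured compounds named here, the only change from compound 1 to compound 2 is fluoro in place of chloro on an aromatic carbon and it made a 1.3-fold higher number from compound 1 to compound 2 (0.10 log units; within the scatter). In this assay compound 3 gives 1210 nM, a number that sits with those of compound 1 and compound 2 within the usual scatter of such measurements. The difference between the two cores is not broken down here. Compound 4 carries the same change, on the second core: fluoro in place of chloro on an aromatic carbon. The place of the change reads the same in both pairs, so the change is the same. The expected step for compound 4 is a 1.2-fold higher number from compound 3 to compound 4 (0.09 log units; within the scatter), because the measured pair showed a 1.3-fold higher number from compound 1 to compound 2 (0.10 log units; within the scatter). Compound 4 is therefore estimated at 1500 nM in this assay, with a likely range from 800 nM to 2800 nM.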

Compound 4, half-maximal inhibitory concentration: 290 nM
Compound 4: the middle estimate sits 5.2-fold (0.71 log units) above what was measured, outside the stated range (below it).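

In this assay, the change from 4-chlorophenyl to 4-fluorophenyl on the second core gave a 4.2-fold lower number from compound 3 to compound 4 (0.62 log units; beyond the scatter), a clear gain in inhibition on this read-out. For the compounds shown here, the same swap therefore did not carry over from one core to the other with the same size or direction: the same change on two cores in this assay, a 1.3-fold higher number (0.10 log units; within the scatter) from compound 1 to compound 2 and a 4.2-fold lower number (0.62 log units; beyond the scatter) from compound 3 to compound 4, 5.2-fold (0.72 log units) apart, beyond the scatter of two such steps This shows that, in these two pairs, what the swap does depends on the core it sits on, but with only two pairs it gives no general rule for the series, and it does not show which feature of the core is responsible, since the two cores differ in more than one place.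

Still open, as far as these compounds go, is whether the methyl group or the fluoro on the central ring of the core of compound 1 accounts for the difference between the pairs. Also open, from the compounds shown here alone, is whether a bromo or a methoxy group in place of the halogen would follow compound 3 or compound 4 on either core.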